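The source may hold more compounds than are shown below. What is called first, only, known or untested is meant among the compounds shown, and "the series" means these compounds.

Working notes on the series in an in vitro ADME assay on microsomes (Homo sapiens) for metabolic stability; a higher number here means that the compound lasts longer, a lower number that the compound disappears faster.

Going by the values given here, compound 1 `CCc1nc(-c2ccc(Cl)cc2Cl)c(CC)nc1SC(C)CC` gives 0.283 h in this assay, which is the lowest of the three numbers measured so far. Compound 2 `CCc1nc(-c2ccc(Cl)cc2Cl)c(OC)nc1NC(CC)CC` gives 0.7 h, a step above compound 1 that lies beyond the usual scatter. Compound 3 `CCOc1ccc(-c2nc(OC)c(NC(CC)CC)nc2C)c(Cl)c1` gives 2 h, the largest of the three numbers and the furthest from compound 1, again beyond the scatter. Among the compounds with values here, compounds 2 and 3 differ from compound 1 in more than one place, so no single-point step is available among the measured compounds.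

Compound 4 `CCc1nc(N(CC2CC2)CC2CC2)c(CC)nc1-c1ccc(Cl)cc1Cl` has not yet been measured. It differs from compound 1 in one place: bis(cyclopropylmethyl)amino in place of (sec-butyl)sulfanyl on an aromatic carbon. Within the data shown here, nothing among the measured compounds isolates this change, so any expectation rests on compound 1 alone and on the general spread of the series. The two other compounds, which carry an amino substituent in the comparable place, both stand higher than compound 1, but they also differ elsewhere, so that is weak guidance. The step from compound 1 to compound 4 is expected to be small and upward, about a 1.4-fold higher number from compound 1 to compound 4 (0.15 log units; within the scatter), roughly within the scatter. Compound 4 is therefore expected to give about 0.4 h in this assay, in a range from 0.15 h to 1.1 h.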

Compound 4, half-life: 0.133 h
Estimate against measurement, compound 4: 3.0-fold (0.48 log units) above, and the stated range ends above it.
By their numbers in this assay, from the lowest: compound 4; then compound 1; then compound 2; then compound 3.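

In this assay, going by these compounds alone, the place on the shared core that holds (sec-butyl)sulfanyl in compound 1 responds to its substituent: bis(cyclopropylmethyl)amino on this aromatic carbon gives a 2.1-fold lower number from compound 1 to compound 4 (0.33 log units; beyond the scatter) as the first step that can be read at a single place. The step is modest, but it is downward, so replacing the sulfur-linked group with this larger nitrogen-linked group, which brings two three-membered rings of carbon, gives no longer half-life on this core. No measurement available here explains the lower number, and this single step cannot separate the change of linking atom from the change in the group's size and shape.

Open, going by these compounds, is whether a smaller amine such as dimethylamino or a sulfur-free ether such as sec-butoxy at the same place would stand with compound 1 or compound 4, which would begin to separate the linking atom from the rest of the group. Also open, on these data alone, is whether the same change would move the number in the same direction on a core that carries methoxy in place of one ethyl group.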